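Alpha-substitution on the alanine amide of the shared core

The compounds below may be only part of what the source reports. "The series", "measured", "known", "first", "only" and "open" are said of these compounds alone.

Of the compounds shown here, three have been tested in an assay on isolated protein for inhibition of protein arginine N-methyltransferase 6 (Homo sapiens) (a higher number here means a weaker inhibitor, a lower number a stronger inhibitor), and all carry the same core, differing only at the carbon that sits on the carbonyl. Compound 1 `C[C@H](N)C(=O)NCc1cccnc1Oc1ccc(F)cc1F` gives 14000 nM in this assay. Compound 2 `C[C@@H](N)C(=O)NCc1cccnc1Oc1ccc(F)cc1F` is reported in this assay as "not active" (no number reported), without a number; the two are separated only by the fact that compounds 1 and 2 differ only in the configuration as drawn, so the drawn configuration is the whole of what sets them apart. Compound 3 `CN[C@@H](C)C(=O)NCc1cccnc1Oc1ccc(F)cc1F` carries a methyl on the amine of the configuration of compound 2. In this assay compound 3 is likewise reported as "not active" (no number reported), again without a number. Compound 3 therefore stands without a single value, and one further entry of the series, compound 2, is in the same position; only compound 1 gives a figure at all.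

Compound 4 `CC(C)(N)C(=O)NCc1cccnc1Oc1ccc(F)cc1F` has not been measured. Its change against compound 3 is 1-amino-1-methylethyl in place of 1-(methylamino)ethyl on a carbonyl carbon, in words 1-amino-1-methylethyl in place of 1-(methylamino)ethyl on a carbonyl carbon, which removes the defined stereocentre. For the measured compounds named here, no measured step exists for this change. Given that compound 1 gives 14000 nM in this assay and the other two entries give no number, weak or absent inhibition is expected for compound 4 as well. Compound 4 is estimated at 30000 nM in this assay, with a range from 8000 nM to 150000 nM.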

Compound 4, half-maximal inhibitory concentration: "not active" (no number reported)
For compound 4 the study gives words and no number, and the estimate cannot be compared.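

No new step can be read: in this assay compound 3 and compound 4 both stand as "not active" (no number reported), so the change from 1-(methylamino)ethyl to 1-amino-1-methylethyl has no size. Nothing at hand accounts for the result of compound 4. The compounds shown leave open whether a methyl on the amine would be tolerated in the configuration of compound 1, which gives 14000 nM.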